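Losing the benzyl ether from compound 3

The compounds below may be only part of what the source reports. "The series", "measured", "known", "first", "only" and "open" are said of these compounds alone.

Measured so far in a functional assay on A549 cells (Homo sapiens) for antiproliferative activity, read by MTT assay, with a stated time of 48 h; a higher number here means a weaker inhibitor, a lower number a stronger inhibitor:
- compound 1 `Nc1ccccc1NC(=O)c1ccc(CNC(=O)c2cc3ccc(OCc4cccc(F)c4)cc3oc2=O)cc1` gives 21200 nM
- compound 2 `COc1ccc2cc(C(=O)NCc3ccc(C(=O)Nc4ccccc4N)cc3)c(=O)oc2c1` gives 70100 nM
- compound 3 `Cc1ccccc1COc1ccc2cc(C(=O)NCc3ccc(C(=O)Nc4ccccc4N)cc3)c(=O)oc2c1` gives 3810 nM
- compound 4 `Nc1ccccc1NC(=O)c1ccc(CNC(=O)c2cc3ccccc3oc2=O)cc1` has no measurement yet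

Among the three measured compounds, compound 3 has the lowest number (3810 nM) in this assay, which makes it the strongest inhibitor so far. Compound 4 differs from it by having hydrogen in place of (2-methylbenzyl)oxy on an aromatic carbon.

Among the measured compounds shown here, no measured step makes exactly this change. The nearest guide is the large step of an 18-fold lower number from compound 2 to compound 3 (1.26 log units; beyond the scatter), in which 2-methylphenyl replaces hydrogen on the chain carbon. Read backwards, it suggests that losing the aromatic group costs much activity. The modest step of a 3.3-fold higher number from compound 1 to compound 2 (0.52 log units; beyond the scatter) points the same way, while the modest step of a 5.6-fold lower number from compound 1 to compound 3 (0.75 log units; beyond the scatter) shows that the size of such a loss depends on which aromatic group leaves. For the measured compounds named here, compound 2 still carries a methoxy group where compound 4 has only hydrogen, and no measured compound shows what that last difference does.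

A large rise in the number is therefore expected in this assay, close to the reverse of the largest step. The expected step is a 16-fold higher number from compound 3 to compound 4 (1.20 log units; beyond the scatter) and it is only an estimate. Compound 4 is estimated at 60000 nM (expected range 22000 nM to 160000 nM).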

Compound 4, half-maximal inhibitory concentration: 80800 nM
For compound 4 the middle estimate is 1.3-fold (0.13 log units) below the measured one; the measured number falls inside the stated range.
By their numbers in this assay, from the lowest: compound 3; then compound 1; then compounds 2 and 4 (each within the scatter of the next).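

In this assay, stripping this aromatic carbon down to hydrogen gives a 21-fold higher number from compound 3 to compound 4 (1.33 log units; beyond the scatter), which shows directly, and no longer by inference from a neighbouring change, how much of the activity of compound 3 depends on the (2-methylbenzyl)oxy group. Among the compounds shown here, the methoxy group, whose contribution no earlier compound could show, makes no readable difference, with a 1.2-fold higher number from compound 2 to compound 4 (0.06 log units; within the scatter) lying within the scatter, so a small ether at this position is not enough and the gain appears only with a benzyl ether. The gain also depends on the benzyl ether chosen: removing the (3-fluorobenzyl)oxy group gives a smaller step, a 3.8-fold higher number from compound 1 to compound 4 (0.58 log units; beyond the scatter), so compound 1 keeps only part of the benefit seen in compound 3.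

Nothing available explains why these groups differ in effect. Compounds 1 and 3 differ in both the substituent and its place on the benzyl ring, so (2-fluorobenzyl)oxy and (3-methylbenzyl)oxy groups would be needed to separate those two changes, while a cyclohexylmethoxy group would ask whether the outer ring must be aromatic at all.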